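Amide nitrogen swap on the bromo core: compound 2 to compound 4

The compounds below may be only part of what the source reports. "The series", "measured", "known", "first", "only" and "open" are said of these compounds alone.

The series is followed in a functional assay on HCT-116 cells (Homo sapiens) for cytotoxicity, read by MTT assay, with a stated time of 72 h; on this read-out higher numbers stand for weaker inhibition and lower numbers for stronger inhibition. Compound 1 `N[C@H]1CC[C@H](Nc2c(C(=O)NCc3ccc(F)cc3)nc(N3CCCCC3)c3cccnc23)CC1` gives 8000 nM in this assay. Compound 2 `N[C@H]1CC[C@H](Nc2c(C(=O)NCc3ccco3)nc(Br)c3cccnc23)CC1` reaches only the limit of this assay, > 10000 nM. Compound 3 `NCCCNc1c(C(=O)NCc2ccc(F)cc2)ncc2cccnc12` likewise reaches only the limit, > 10000 nM. Among the measured compounds shown here, compound 2 thus stands at the limit of > 10000 nM in this assay, at which 2 of the 3 values shown sit, with no number of its own, and no measured step joins any two compounds here. Compound 4 `N[C@H]1CC[C@H](Nc2c(C(=O)Nc3ccccc3)nc(Br)c3cccnc23)CC1` differs from compound 2 in one place: phenyl in place of (furan-2-yl)methyl on an amide-type nitrogen, that is, anilino in place of ((furan-2-yl)methyl)amino. With compound 2 at the limit, no step beyond the scatter is expected in this assay. The estimated step that the limit leaves unreadable from compound 2 to compound 4 is small. Compound 4 is expected to give about 12000 nM, between 4000 nM and 40000 nM, most likely again only a limit.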

Compound 4, half-maximal inhibitory concentration: 2000 nM
Compound 4: middle estimate off by 6.0-fold (0.78 log units), on the high side; the whole stated range lies above it.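

On the shared core, the group on the amide-type nitrogen does affect the read-out in this assay: phenyl in place of (furan-2-yl)methyl gives an at least 5.0-fold lower number from compound 2 to compound 4 (0.69 log units; beyond the scatter). Among the compounds shown here, this is the only readable single-place step in the set, and it shows that this position can move the value beyond the scatter. Compound 2 has only a limit, so the step gives a minimum and no exact size: the limit of > 10000 nM in this assay, at which 2 of the 4 values shown sit.

As far as these compounds go, it remains open whether the ring exchange or the removal of the methylene link carries the step. A plain benzyl group on this nitrogen of the bromo core would separate the two.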